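The compounds below may be only part of what the source reports. "The series", "measured", "known", "first", "only" and "open" are said of these compounds alone.

In a functional assay on K-562R cells (Homo sapiens) for cytotoxicity, read by MTT assay, with a stated time of 48 h (a lower number here means a stronger inhibitor, a higher number a weaker inhibitor), compound 1 `COc1ccc(-c2c[nH]c(=O)n2-c2cc(OC)c(OC)c(OC)c2)cc1OC` gives > 50000 nM, which is a limit of the assay and not a number. Compound 2 `COc1cc(NC(=O)n2cc(-c3ccc(O)cc3)n(-c3cc(OC)c(OC)c(OC)c3)c2=O)cc(OC)c1OC` also gives only a limit, > 50000 nM. Both compounds therefore sit at the same limit: the limit of > 50000 nM in this assay, at which 2 of the 2 values shown sit. Compound 3 `COc1ccc(-c2cn(C(=O)Nc3cc(OC)c(OC)c(OC)c3)c(=O)n2-c2cc(OC)c(OC)c(OC)c2)cc1` differs from compound 2 in one place, with 4-methoxyphenyl in place of 4-hydroxyphenyl: methyl in place of hydrogen on an oxygen on an aromatic ring. Compound 2 stands at the limit of > 50000 nM, so compound 3 is expected to remain weak. The estimated step of a number no higher from compound 2 to compound 3 (the limit leaves the size open) is expected to stay within the scatter in this assay. For compound 3 the expected value is 50000 nM, with an estimated range from 20000 nM to 100000 nM.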

Compound 3, half-maximal inhibitory concentration: 3500 nM
Estimate against measurement, compound 3: 14-fold (1.15 log units) above; measured number below the stated range.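

Changing 4-hydroxyphenyl to 4-methoxyphenyl gives an at least 14-fold lower number from compound 2 to compound 3 (1.15 log units; beyond the scatter) in this assay. This shows that the group on this oxygen matters: a single methyl in place of hydrogen is enough to bring a compound from the limit to a measurable value. The true size of the step stays open, because compound 2 gives only a limit of the assay: the limit of > 50000 nM in this assay, at which 2 of the 3 values shown sit.

Going by these compounds, whether a longer chain such as ethyl on this oxygen, or an amine in place of the hydroxy group, would give a similar value stays open. Why the methyl has this effect also stays open.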